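The source may hold more compounds than are shown below. What is called first, only, known or untested is meant among the compounds shown, and "the series" means these compounds.

Measured so far in an ADME assay on PANC-1 cells (Homo sapiens) for cytotoxicity, read by MTT assay, with a stated time of 48 h; a higher number here means a weaker inhibitor of growth, a lower number a stronger inhibitor of growth:
Compound 1 `O=C(/C=C\c1ccccc1)N1N=C(c2ccncc2)OC1c1c[nH]c2ccccc12` gives only the limit of the assay, > 30 ug/mL.
Compound 2 `O=C(/C=C\c1ccccc1O)N1N=C(c2ccncc2)OC1c1c[nH]c2ccccc12` gives only the limit of the assay, > 30 ug/mL.
Compound 3 `O=C(/C=C\c1ccccc1[N+](=O)[O-])N1N=C(c2ccncc2)OC1c1c[nH]c2ccccc12` gives only the limit of the assay, > 30 ug/mL.

Compound 3 therefore stands nowhere that can be ranked: its value is a limit, and the two other values shown are limits as well, so that all three sit at the same place, as stated by the limit of > 30 ug/mL in this assay, at which 3 of the 3 values shown sit. The steps between the measured compounds, a step that the two limits leave unreadable from compound 1 to compound 2, a step that the two limits leave unreadable from compound 1 to compound 3 and a step that the two limits leave unreadable from compound 2 to compound 3, are all left unreadable by the limits on both sides, so no size can be put on them.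

Compound 4 `O=C(/C=C\c1cccc([N+](=O)[O-])c1)N1N=C(c2ccncc2)OC1c1c[nH]c2ccccc12` is the next compound, and it differs from compound 3 by 3-nitrophenyl in place of 2-nitrophenyl on a double-bonded chain carbon bound to a double-bonded chain carbon. For the measured compounds named here, none of the measured steps touches this change directly, and the three that exist cannot be read in size, so they give no direction. With every value shown resting at the limit, as the limit of > 30 ug/mL in this assay, at which 3 of the 3 values shown sit, records, the expectation for compound 4 is that the step that the limit leaves unreadable from compound 3 to compound 4 shows nothing beyond the scatter. Compound 4 is therefore estimated at 40 ug/mL, within a range from 15 ug/mL to 100 ug/mL, and most probably the assay will again report only a limit.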

Compound 4, concentration for 50% growth inhibition: > 30 ug/mL
Compound 4 was reported as a limit; the forecaster's own chance of this, stated with the estimate: 80%; the middle value lies beyond the limit too.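

For the compounds shown here, compound 4 also gives only a limit in this assay, so no step between it and compound 1, compound 2 or compound 3 can be read: the limit of > 30 ug/mL in this assay, at which 4 of the 4 values shown sit.

The compounds shown leave open whether any of these changes to the shared core, including 3-nitrophenyl in place of 2-nitrophenyl, alters growth inhibition in this assay at all.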